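A few compounds are considered here, and "the series" means these few. Any claim that something is new, unique, unknown or untested is made for them only; others in the source may bear on it.

Measured so far in a functional assay on RAW264.7 cells (Mus musculus) for inhibition, read by Griess assay, with a stated time of 24 h; on this read-out lower numbers stand for stronger inhibition and higher numbers for weaker inhibition:
- compound 1 `CC1=C[C@]2(O)O[C@@]3(CC2=C(C)C)[C@@H](C)CC[C@@H]13`: 4200 nM
- compound 2 `CC1=CC(=O)[C@@]2(C[C@]3(O)[C@@H](C)CC[C@@H]13)OC2(C)C`: 57400 nM

Compound 1 holds the lowest number of the two; compound 2 sits far above it, a gap beyond the scatter. The two structures are not a single-change pair, so nothing is drawn from that gap beyond the two values themselves.

Compound 3 `CC1=C[C@@]2(O)O[C@@]3(CC2=C(C)C)[C@H](C)CC[C@@H]13` is still unmeasured. Against compound 1 the change is the two compounds have the same atoms and bonds and differ only in configuration as drawn: 2 of 4 stereo elements differ; a stereocentre at a saturated ring carbon is drawn S in compound 1 and R in compound 3; a stereocentre at a saturated ring carbon is drawn S in compound 1 and R in compound 3. Going by the values given here, no measured pair of this kind is available, so the size of the step is unknown from the data; an inversion at two saturated ring carbons of the shared core is taken here to be more likely to weaken than to strengthen, with a wide margin, and a step within the scatter is possible. The expected step from compound 1 to compound 3 is a 2.1-fold higher number from compound 1 to compound 3 (0.33 log units; beyond the scatter). Compound 3 is estimated at 9000 nM, expected between 2500 nM and 40000 nM.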

Compound 3, half-maximal inhibitory concentration: 52200 nM
Compound 3: the middle estimate sits 5.8-fold (0.76 log units) below what was measured, and the stated range ends below it.
By their numbers in this assay, from the lowest: compound 1; then compounds 3 and 2 (each within the scatter of the next).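

In this assay, inverting two saturated ring carbons of the shared core gives a 12-fold higher number from compound 1 to compound 3 (1.09 log units; beyond the scatter). Going by these compounds alone, this is the first step that can be read across a single kind of change, and it shows that configuration at these carbons alone is enough to move the number well beyond the scatter, with the arrangement drawn in compound 1 holding the lower value. The step can be placed on configuration and on nothing else, because no atom or bond separates the pair: the fact that compounds 1 and 3 differ only in the configuration as drawn

On these data alone, both stereocentres change together, so how much of the step belongs to each one stays open, as does whether a single inversion would suffice. Also open, as far as these compounds go, is how an amine or a carboxylic acid on the shared core would read out in either configuration.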